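Bromo to iodo at the chain carbon, two cores

The source may hold more compounds than are shown below. What is called first, only, known or untested is meant among the compounds shown, and "the series" means these compounds.

Compound 1 `Cc1ccc(NC(=O)CBr)cc1C(=O)NC(N)=O` and compound 2 `COC(=O)c1cc(NC(=O)CBr)cc(C(=O)NC(N)=O)c1` carry the same bromo-bearing arm on different cores; the difference between the two cores is not broken down here. In a functional assay on CCRF-CEM cells (Homo sapiens) for antiproliferative activity, read by trypan blue exclusion, with a stated time of 72 h (a lower number here means a stronger inhibitor, a higher number a weaker inhibitor), compound 1 gives 4760 nM and compound 2 gives 1300 nM, the lowest of the three numbers measured. Compound 3 `Cc1ccc(NC(=O)CI)cc1C(=O)NC(N)=O` is the counterpart of compound 1 with iodo in place of bromo on a saturated chain carbon bound to a carbonyl carbon; in this assay compound 3 gives 20000 nM, and that change made a 4.2-fold higher number from compound 1 to compound 3 (0.62 log units; beyond the scatter). Compound 4 `COC(=O)c1cc(NC(=O)CI)cc(C(=O)NC(N)=O)c1` has not been measured; it carries iodo in place of bromo on a saturated chain carbon bound to a carbonyl carbon on the core of compound 2. The two changes sit at the same place, word for word, so they are the same change made twice, once on each core. Among the compounds with values here, the single measured step is the only guide for compound 4, and it is expected to carry over in rough size; the step from compound 2 to compound 4 is estimated at a 4.2-fold higher number from compound 2 to compound 4 (0.63 log units; beyond the scatter), resting on a 4.2-fold higher number from compound 1 to compound 3 (0.62 log units; beyond the scatter). Within the data shown here, compound 4 is accordingly expected to give about 5500 nM in this assay, with a range from 2000 nM to 16000 nM, because compound 2 gives 1300 nM and the one measured example of the change made a 4.2-fold higher number from compound 1 to compound 3 (0.62 log units; beyond the scatter). Among the measured compounds shown here, the width of that range reflects that only one example of the change is known.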

Compound 4, half-maximal inhibitory concentration: 1910 nM
Compound 4: the middle estimate sits 2.9-fold (0.46 log units) above what was measured; the whole stated range lies above it.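

Iodo in place of bromo on a saturated chain carbon bound to a carbonyl carbon reads a 1.5-fold higher number from compound 2 to compound 4 (0.17 log units; within the scatter) in this assay, a step that does not separate the pair. Set beside the earlier step, the same change does not carry over in size from one core to the other: the same change on two cores in this assay, a 4.2-fold higher number (0.62 log units; beyond the scatter) from compound 1 to compound 3 and a 1.5-fold higher number (0.17 log units; within the scatter) from compound 2 to compound 4, 2.9-fold (0.46 log units) apart, beyond the scatter of two such steps Each core supplies a single pair, so the data show that the size of this step depends on the core in these two cases, but they do not show what in the cores sets the two apart, or how the change would read on any further core.

Open, as far as these compounds go, is how a chloro group on that saturated chain carbon, or a longer chain in place of bromomethyl, would read on either core in this assay. Also open, from the compounds shown here alone, is whether an amine in place of the halogen would keep any of the antiproliferative activity seen with bromo and iodo.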